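Adding a methyl to the terminal piperidine ring

A few compounds are considered here, and "the series" means these few. Any claim that something is new, unique, unknown or untested is made for them only; others in the source may bear on it.

Of the compounds shown here, two measured so far share one core and differ only in the amine at the end of a three-carbon chain. Compound 1 `COc1cc2c(Oc3ccc(NC(=O)c4nnn(-c5ccc(F)cc5)c4C(F)(F)F)cc3F)ccnc2cc1OCCCN1CCCC1` carries a pyrrolidin-1-yl group, and in a functional assay on NCI-H460 cells (Homo sapiens) for cytotoxicity, read by MTT assay, with a stated time of 72 h (a lower number here means a stronger inhibitor, a higher number a weaker inhibitor), compound 1 gives 150 nM. Compound 2 `COc1cc2c(Oc3ccc(NC(=O)c4nnn(-c5ccc(F)cc5)c4C(F)(F)F)cc3F)ccnc2cc1OCCCN1CCCCC1` carries a piperidin-1-yl group in its place, and in this assay compound 2 gives 190 nM. That change gave a 1.3-fold higher number from compound 1 to compound 2 (0.10 log units; within the scatter), so the number for compound 2 sits within the scatter of the number for compound 1, and neither can be called different from the other.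

Compound 3 `COc1cc2c(Oc3ccc(NC(=O)c4nnn(-c5ccc(F)cc5)c4C(F)(F)F)cc3F)ccnc2cc1OCCCN1CCC(C)CC1` has not yet been measured. It differs from compound 2 by methyl in place of hydrogen on a saturated ring carbon. Among the compounds with values here, the only measured step that touches this part of the molecule is a 1.3-fold higher number from compound 1 to compound 2 (0.10 log units; within the scatter), which altered the same amine ring and left the number within the scatter. Nothing seen so far shows a change at this terminal amine moving the number beyond the scatter, so the step of a 1.1-fold higher number from compound 2 to compound 3 (0.02 log units; within the scatter) is expected to be small. Compound 3 is therefore estimated at 200 nM, with a likely range from 90 nM to 450 nM.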

Compound 3, half-maximal inhibitory concentration: 190 nM
Estimate against measurement, compound 3: 1.1-fold (0.02 log units) above, and the stated range covers the measured number.
By their numbers in this assay, from the lowest: compounds 1, 2 and 3 (each within the scatter of the next).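

In this assay, within the data shown here, a methyl on a saturated ring carbon, three ring bonds from the ring nitrogen, gave no change at the digits printed from compound 2 to compound 3 (within the scatter) when it replaced hydrogen, so this is the first look at a substituent on the terminal ring rather than a change in the ring itself. Set against the pyrrolidin-1-yl group of the first compound, the 4-methylpiperidin-1-yl group gave a 1.3-fold higher number from compound 1 to compound 3 (0.10 log units; within the scatter) when it came in, which means that all three terminal amines shown here, differing in ring size or in one added carbon, cannot be told apart in this assay. Nothing available here accounts for this lack of separation, and no independent measurement bears on it.

A single methyl is a small probe, so these compounds leave open whether a hydroxyl, a carboxylic acid, a phenyl ring or a second ring nitrogen at the same ring position would move the number beyond the scatter. They also leave open what a methyl on a different ring carbon, an open-chain dimethylamine or a longer chain to the amine would do.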